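Dichlorophenoxy in Place of Dimethoxyphenoxymethyl on the Shared Chain

The compounds below may be only part of what the source reports. "The series", "measured", "known", "first", "only" and "open" are said of these compounds alone.

Two measured compounds frame this step. In an in vitro functional assay on HEK ts201 cells for antagonist activity at Neuronal acetylcholine receptor; alpha4/beta2 (Homo sapiens), read by fluorescence and calcium flux (on this read-out lower numbers stand for stronger inhibition and higher numbers for weaker inhibition), compound 1 `COc1cccc(OCCCCCN2CCCC(COC(=O)c3ccccc3N3C(=O)CC(C)C3=O)C2)c1OC` gives 8710 nM, and compound 2 `O=C(NCc1cccc2ccccc12)c1ccccc1-c1ccccc1` gives 13900 nM. Compound 1 holds the lower of these two numbers, yet its gap to compound 2 lies within the scatter, so the two stand level. Compound 3 `CC1CC(=O)N(c2ccccc2C(=O)OCC2CCCN(CCCCOc3ccc(Cl)c(Cl)c3)C2)C1=O` differs from compound 1 at one point: 3,4-dichlorophenoxy in place of (2,3-dimethoxyphenoxy)methyl on a saturated chain carbon, four bonds along the chain from an amine nitrogen in a ring. Among the measured compounds shown here, no step between measured compounds shows how this assay answers such an exchange, so no shift beyond the scatter is expected. Compound 3 is estimated at 8000 nM, within 2500 nM to 25000 nM. The expected step is a 1.1-fold lower number from compound 1 to compound 3 (0.04 log units; within the scatter).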

Compound 3, half-maximal inhibitory concentration: 12300 nM
The estimate for compound 3 lay 1.5-fold (0.19 log units) below the measured number; the range from low to high includes it.
By their numbers in this assay, from the lowest: compounds 1, 3 and 2 (each within the scatter of the next).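

Setting 3,4-dichlorophenoxy in place of (2,3-dimethoxyphenoxy)methyl on a saturated chain carbon, four bonds along the chain from an amine nitrogen in a ring, gives a 1.4-fold higher number from compound 1 to compound 3 (0.15 log units; within the scatter) in this assay and supplies the first reading at this position. Here, the exchange of one aryl ether group for the other, which removes the two methoxy groups and brings in two chlorine atoms, leaves the number level. No measurement on hand bears on this result.

The compounds shown leave open how this assay answers a carboxylic acid or a primary amine at this position. They also leave open whether a longer chain would leave the number level.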